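The compounds below may be only part of what the source reports. "The series", "measured", "known", "first", "only" and "open" are said of these compounds alone.

Measured compounds in a functional assay on A549 cells (Homo sapiens) for antiproliferative activity, read by sulforhodamine B assay, with a stated time of 72 h; a higher number here means a weaker inhibitor, a lower number a stronger inhibitor:
Compound 1 `COc1ccc(/C=C2\CCC=CC2=O)cc1` gives 1460 nM.
Compound 2 `COc1ccc(/C=C2\CCC=CC2=O)c(C)c1` gives 1550 nM.
Compound 3 `COc1cc(/C=C2\CN(S(=O)(=O)c3ccccc3)C=CC2=O)cc(OC)c1OC` gives 22400 nM.

Compound 1 and compound 2 share a core and differ only by methyl in place of hydrogen on an aromatic carbon. This change made a step of a 1.1-fold higher number from compound 1 to compound 2 (0.03 log units; within the scatter), so the two numbers are not told apart. Compound 3 gives the highest number of the three, and its separation from compound 1 and from compound 2 is beyond the scatter. How the core of compound 3 differs from the core of compound 1 is not broken down here.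

Compound 4 `COc1cc(/C=C2\CN(S(=O)(=O)c3ccc(C)cc3)C=CC2=O)cc(OC)c1OC` has not yet been measured. It differs from compound 3 by methyl in place of hydrogen on an aromatic carbon. This is the same kind of change as that from compound 1 to compound 2, not the same change: in compound 2 the methyl sits ortho to a group of 8 heavy atoms and meta to a methoxy group, whereas in compound 4 it sits para to a large group. The expectation for compound 4 rests on compound 2, whose step of a 1.1-fold higher number from compound 1 to compound 2 (0.03 log units; within the scatter) stayed within the scatter, and on the value of compound 3 at 22400 nM. Compound 4 is therefore expected to sit close to its parent, with an estimated step of a 1.0-fold lower number from compound 3 to compound 4 (0.01 log units; within the scatter). Compound 4 is estimated at 22000 nM in this assay, expected between 8000 nM and 60000 nM.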

Compound 4, half-maximal inhibitory concentration: 20200 nM
The estimate for compound 4 lay 1.1-fold (0.04 log units) above the measured number; low and high end bracket the measured number.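

In this assay, methyl in place of hydrogen on an aromatic carbon gave a 1.1-fold lower number from compound 3 to compound 4 (0.04 log units; within the scatter), so the number for compound 4 cannot be told apart from that of its parent. Set beside the earlier case, the change made no discernible difference on either of the two cores, and the two steps agree: the same change on two cores in this assay, a 1.1-fold higher number (0.03 log units; within the scatter) from compound 1 to compound 2 and a 1.1-fold lower number (0.04 log units; within the scatter) from compound 3 to compound 4, 1.2-fold (0.07 log units) apart, within the scatter of two such steps. This shows that the change left the number unresolved from its parent in two settings, one of them para to a large group, but it rests on a single pair per core and does not show that the same would hold at other places on the ring or on other cores.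

The compounds shown leave open whether a group other than methyl at this place on the phenylsulfonyl group, such as an amine, a carboxylic acid or a longer chain, would separate a compound from compound 3. They also leave open whether any such group would act alike on the core of compound 1.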